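The source may hold more compounds than are shown below. What is called first, only, known or untested is meant among the compounds shown, and "the series" means these compounds.

Compound 1 `CC1CCCC(C(=O)N2CC(c3nc(-c4cccc(Cl)c4)no3)C2)C1`: > 10000 nM
Compound 2 `O=C(c1cccc(F)c1)N1CC(c2nc(-c3cccc(Cl)c3)no2)C1`: 780 nM

In an assay on HEK293 cells for negative allosteric modulation of metabotropic glutamate receptor 5 (Homo sapiens), read by FLIPR (a lower number here means a stronger inhibitor, a higher number a weaker inhibitor), compound 1 gives a limit of the measurement rather than a number, > 10000 nM. Compound 2 in this assay gives 780 nM, the only definite number shown. Compound 3 `O=C(C1CCC1)N1CC(c2nc(-c3cccc(Cl)c3)no2)C1` differs from compound 2 by cyclobutyl in place of 3-fluorophenyl on a carbonyl carbon. Within the data shown here, the one measured step bearing on this, an at least 12-fold lower number from compound 1 to compound 2 (1.10 log units; beyond the scatter), replaced a saturated ring with an aromatic one and was large; the present change runs the other way, back to a saturated ring. For compound 3 the expected step is a 6.4-fold higher number from compound 2 to compound 3 (0.81 log units; beyond the scatter), towards a weaker inhibitor. Compound 3 is estimated at 5000 nM, between 1500 nM and 20000 nM.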

Compound 3, half-maximal inhibitory concentration: 1500 nM
Estimate against measurement, compound 3: 3.3-fold (0.52 log units) above; low and high end bracket the measured number.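

In this assay, an aromatic ring on the carbonyl carbon is not needed to keep this level of activity: cyclobutyl in place of 3-fluorophenyl gives a 1.9-fold higher number from compound 2 to compound 3 (0.28 log units; within the scatter). Saturated rings at this position also do not behave alike, as cyclobutyl in place of 3-methylcyclohexyl gives an at least 6.6-fold lower number from compound 1 to compound 3 (0.82 log units; beyond the scatter). Compound 1 gives a limit rather than a number, so that step has no upper end: the limit of > 10000 nM in this assay, at which 1 of the 3 values shown sits.

Still open, going by these compounds, is how an unbranched butyl chain, a cyclopentyl ring or an amine on the carbonyl carbon would compare.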